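Swapping One Five-Membered Ring for Another

The source may report more compounds than this note shows. Statements on the series, on what has been measured and on what is new or still open speak of the compounds shown alone.

Three measured compounds share one core and differ only in the aromatic ring attached to it. In a functional assay on CCRF-CEM cells (Homo sapiens) for cytotoxicity, read by XTT assay, with a stated time of 3 days (on this read-out higher numbers stand for weaker inhibition and lower numbers for stronger inhibition), compound 1 `OC[C@H]1O[C@@H](n2cc(F)c3c(-c4ccccc4)ncnc32)[C@H](O)[C@@H]1O`, which carries phenyl, gives 3100 nM. Compound 3 `OC[C@H]1O[C@@H](n2cc(F)c3c(-c4nccs4)ncnc32)[C@H](O)[C@@H]1O`, which carries 1,3-thiazol-2-yl, gives 550 nM. Compound 2 `OC[C@H]1O[C@@H](n2cc(F)c3c(-c4cccs4)ncnc32)[C@H](O)[C@@H]1O`, which carries thiophen-2-yl, gives 270 nM, the lowest of the three numbers and so the strongest inhibition in the set.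

Compound 4 `OC[C@H]1O[C@@H](n2cc(F)c3c(-c4ccoc4)ncnc32)[C@H](O)[C@@H]1O` has furan-3-yl in place of thiophen-2-yl on an aromatic carbon. Among the measured compounds shown here, no measured compound carries furan-3-yl, so the evidence is indirect. Replacing phenyl with a five-membered ring gave a large change, an 11-fold lower number from compound 1 to compound 2 (1.06 log units; beyond the scatter), and a modest one, a 5.6-fold lower number from compound 1 to compound 3 (0.75 log units; beyond the scatter). Exchanging one five-membered ring for another moved the number much less, a 2.0-fold higher number from compound 2 to compound 3 (0.31 log units; beyond the scatter). The new change is also an exchange of one five-membered ring for another, so it resembles that last, smaller step. A small rise or no change beyond the scatter is therefore expected, and the estimated step is a 1.3-fold higher number from compound 2 to compound 4 (0.11 log units; within the scatter). For compound 4 the expected value is 350 nM, with an estimated range from 110 nM to 1100 nM.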

Compound 4, half-maximal inhibitory concentration: 1000 nM
Estimate against measurement, compound 4: 2.9-fold (0.46 log units) below, and the stated range covers the measured number.
By their numbers in this assay, from the lowest: compound 2; then compounds 3 and 4 (each within the scatter of the next); then compound 1.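

At this position, one five-membered ring in place of another need not be a quiet exchange: in this assay the change gives a 3.7-fold higher number from compound 2 to compound 4 (0.57 log units; beyond the scatter) even though thiophen-2-yl and furan-3-yl have the same counts of heavy atoms, hetero atoms, donors and acceptors, so those counts do not account for the difference in the numbers. Furan-3-yl still improves on phenyl, with a 3.1-fold lower number from compound 1 to compound 4 (0.49 log units; beyond the scatter) on the same read-out, which makes it the third five-membered ring shown here to give a lower number than the phenyl of compound 1. The remaining comparison, a 1.8-fold higher number from compound 3 to compound 4 (0.26 log units; within the scatter), lies within the scatter, so compound 3 and compound 4 cannot be told apart, and compound 2 now stands clear of all three other compounds.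

Nothing available here explains why the thiophen-2-yl and furan-3-yl compounds differ. This single step also changes two things at once, the hetero atom and the ring's point of attachment, so thiophen-3-yl or furan-2-yl would be needed to separate them, while an amine or a short alkyl chain here would test whether an aromatic ring is needed at all.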